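Allyl in place of sec-butyl on the amide nitrogen

This account rests on a few compounds, and the source may have more. Where it says the series, first, only, none or still open, it means among the compounds named here.

Compound 2 `CCC(C)NC(=O)/C=C/c1ccccc1` gives 77% in a functional assay on the whole organism for inhibition, with Brassica rapa subsp. chinensis as the target, with a stated time of 3 days, tested at 100 ppm; a higher number here means more inhibition of growth at the concentration tested, a lower number less inhibition of growth. Among the measured compounds shown here, only one other compound has been measured: compound 1 `CC(C)NC(=O)/C=C/c1ccccc1`, which in this assay gives 76%. The step of a number 1 percentage points higher from compound 1 to compound 2 (within the scatter) is within the scatter, so although compound 2 carries the numerically upper of the two figures, the two compounds cannot be told apart on these data.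

Compound 3 `C=CCNC(=O)/C=C/c1ccccc1` differs from compound 2 by allyl in place of sec-butyl on an amide-type nitrogen. For the measured compounds named here, no measured step touches this exchange of one nitrogen substituent for another; the only step known, a number 1 percentage points higher from compound 1 to compound 2 (within the scatter), concerns a methyl on the saturated chain and did not move the read-out beyond the scatter. With nothing pointing either way, the expected step of a number 2 percentage points lower from compound 2 to compound 3 (within the scatter) is none beyond the scatter. Compound 3 is therefore estimated at 75% in this assay, with a range from 60% to 88%.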

Compound 3, percent growth inhibition at one concentration: 64%
For compound 3 the middle estimate is 11 percentage points above the measured one, within the range that was stated.
By their numbers in this assay, from the lowest: compound 3; then compounds 1 and 2 (each within the scatter of the next).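

In this assay the substituent on the amide-type nitrogen can clearly move the read-out, which the step between the two saturated groups did not show: allyl in place of sec-butyl gives a number 13 percentage points lower from compound 2 to compound 3 (beyond the scatter) and allyl in place of isopropyl gives a number 12 percentage points lower from compound 1 to compound 3 (beyond the scatter) in the same direction. Compound 3 is thus the first of these compounds to stand apart from the others beyond the scatter. Nothing available explains why allyl gives the lower figure.

The compounds shown leave open whether the lower figure goes with the double bond of allyl or with its carbon count, as the two differences arrive together in compound 3. An n-propyl group on the same nitrogen would separate them, and a longer chain such as n-hexyl remains an open case.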